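Swapping the Pyridine Ester of Compound 3 for a Carboxyphenyl

The source may hold more compounds than are shown below. What is called first, only, known or untested is meant among the compounds shown, and "the series" means these compounds.

In an ADME assay on HepG2 2.2.15 cells (Homo sapiens) for cytotoxicity, read by MTT assay (on this read-out higher numbers stand for lower toxicity in this test and lower numbers for higher toxicity in this test), compound 1 `C=C1CC[C@@H]2[C@](C)(COC(=O)c3cccnc3)[C@H](O)CC[C@@]2(C)[C@@H]1/C=C/C1=CCOC1=O` gives 113000 nM, while compound 3 `C=C1CC[C@@H]2[C@](C)(COC(=O)c3cccnc3)[C@H](O)CC[C@@]2(C)[C@@H]1C/C=C1\C=COC1=O` gives 2050000 nM, the higher of the two exact numbers. Compound 2 `C=C1CC[C@@H]2[C@](C)(COC(=O)CCCC(=O)O)[C@H](OC(=O)CCCC(=O)O)CC[C@@]2(C)[C@@H]1/C=C/C1=CCOC1=O` gives only a limit, > 1710000 nM. Compound 4 `C=C1CC[C@@H]2[C@](C)(COC(=O)c3ccccc3C(=O)O)[C@H](O)CC[C@@]2(C)[C@@H]1C/C=C1\C=COC1=O` keeps the rest of compound 3 but carries 2-carboxyphenyl in place of pyridin-3-yl on a carbonyl carbon. Going by the values given here, the only measured step, an 18-fold higher number from compound 1 to compound 3 (1.26 log units; beyond the scatter), is large, but it changes a different part of the molecule, so it gives no size for this swap. The expected step is therefore a 1.1-fold lower number from compound 3 to compound 4 (0.06 log units; within the scatter), with no clear direction and nothing expected beyond the scatter. For compound 4, the estimated value is 1800000 nM, with an expected range from 700000 nM to 4000000 nM.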

Compound 4, half-maximal cytotoxic concentration: 450000 nM
For compound 4 the middle estimate is 4.0-fold (0.60 log units) above the measured one; measured number outside the range, below it.
By their numbers in this assay, from the lowest: compound 1; then compound 4; then compound 3.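

In this assay, this carbonyl carbon proves sensitive to the group it carries: 2-carboxyphenyl in place of pyridin-3-yl brings a 4.6-fold lower number from compound 3 to compound 4 (0.66 log units; beyond the scatter), meaning higher toxicity in this test. Going by these compounds alone, the earlier step changed a different part of the molecule, so this is the first size seen for a change here. No measurement shown accounts for the step. From the compounds shown here alone, whether the carboxylic acid or the carbon-only aromatic ring matters more stays open. A plain phenyl or a 2-(methoxycarbonyl)phenyl at this place would separate the two.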